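Butylsulfanyl for hexyloxy: cytotoxicity limits in the series

This account rests on a few compounds, and the source may have more. Where it says the series, first, only, none or still open, it means among the compounds named here.

- compound 1 `CC(C)Nc1nc(N)nc2c1ncn2/C=C1/CC1(CO)CO`: > 300000 nM
- compound 2 `CCCCCCSc1nc(N)nc2c1ncn2/C=C1/CC1(CO)CO`: > 300000 nM
- compound 3 `CCCCCCOc1nc(N)nc2c1ncn2/C=C1/CC1(CO)CO`: > 200000 nM

All three values are limits of an ADME assay on HFF cells (Homo sapiens) for cytotoxicity, with a stated time of 8 days (on this read-out lower numbers stand for higher toxicity in this test and higher numbers for lower toxicity in this test), not numbers. Compound 3 gives > 200000 nM, which is a limit. It stands at the limit of > 200000 nM in this assay, at which 1 of the 3 values shown sits, while compound 1 and compound 2 stand at the limit of > 300000 nM in this assay, at which 2 of the 3 values shown sit.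

Compound 4 `CCCCSc1nc(N)nc2c1ncn2/C=C1/CC1(CO)CO` follows from butylsulfanyl in place of hexyloxy on an aromatic carbon. The closest measured change is a step that the two limits leave unreadable from compound 2 to compound 3, which also exchanges a sulfanyl chain and an oxy chain. Also relevant are a step that the two limits leave unreadable from compound 1 to compound 2 and a step that the two limits leave unreadable from compound 1 to compound 3. None of these steps has a readable size, so the expectation rests on the limits alone. Compound 2, which carries hexylsulfanyl, gives > 300000 nM, again a limit.

No step beyond the scatter is expected, and a further limit is the likely report. The expected change is a step that the limit leaves unreadable from compound 3 to compound 4. For compound 4 the estimated value is 250000 nM, with an expected range from 90000 nM to 320000 nM.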

Compound 4, half-maximal cytotoxic concentration: > 300000 nM
Compound 4: a limit, no number (the forecaster's own chance of this, stated with the estimate: 80%); at least 1.2-fold (0.07 log units) between middle value and limit.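

In this assay compound 4 gives > 300000 nM, a limit. Its steps from compound 1, compound 2 and compound 3 cannot be read. The compounds shown leave open how the isopropylamino, hexylsulfanyl, hexyloxy and butylsulfanyl compounds rank, since none has a readable number.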